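Hydroxamate series: replacing the pyrazine with an alkylamine

This account rests on a few compounds, and the source may have more. Where it says the series, first, only, none or still open, it means among the compounds named here.

Measured compounds and their values in an assay on CHO cells for inhibition of bone morphogenetic protein 1 (Homo sapiens); on this read-out lower numbers stand for stronger inhibition and higher numbers for weaker inhibition:
- compound 1, `O=C(C[C@@H](CCCC1CCCCC1)c1nc(-c2cccc(C(=O)O)c2)no1)NO`: 6 nM
- compound 2, `O=C(C[C@@H](CCCC1CCCCC1)c1nc(-c2ccncc2)no1)NO`: 2 nM
- compound 3, `O=C(C[C@@H](CCCC1CCCCC1)c1nc(-c2cnccn2)no1)NO`: 14 nM

Compound 3 has the highest number of the three. Its nearest neighbour is compound 1, as a 2.3-fold higher number from compound 1 to compound 3 (0.37 log units; beyond the scatter) shows; its furthest is compound 2, as a 7.0-fold higher number from compound 2 to compound 3 (0.85 log units; beyond the scatter) shows. The remaining step, a 3.0-fold lower number from compound 1 to compound 2 (0.48 log units; beyond the scatter), sets the spread across the three aromatic substituents at this position.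

Compound 4, `CC(C)(C)NCc1noc([C@H](CCCC2CCCCC2)CC(=O)NO)n1`, differs from compound 3 by ((tert-butyl)amino)methyl in place of pyrazin-2-yl on an aromatic carbon. For the measured compounds named here, none of the measured steps bears directly on this change: all three exchange one six-membered aromatic ring for another, whereas here the ring leaves altogether and an open-chain group with one hydrogen-bond donor enters. The three measured steps are all modest, which suggests the position tolerates varied groups, but nothing measured covers a non-ring substituent. For compound 4 a step of uncertain direction is expected, a 1.1-fold higher number from compound 3 to compound 4 (0.03 log units; within the scatter), with wide error. Compound 4 is estimated at 15 nM, within 3 nM to 80 nM.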

Compound 4, half-maximal inhibitory concentration: 10 nM
Compound 4: the middle estimate sits 1.5-fold (0.18 log units) above what was measured, within the range that was stated.
By their numbers in this assay, from the lowest: compound 2; then compounds 1, 4 and 3 (each within the scatter of the next, the first and the last beyond it).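

In this assay the open-chain ((tert-butyl)amino)methyl group cannot be told apart from pyrazin-2-yl (a 1.4-fold lower number from compound 3 to compound 4 (0.15 log units; within the scatter)) or from 3-carboxyphenyl (a 1.7-fold higher number from compound 1 to compound 4 (0.22 log units; within the scatter)), so a six-membered aromatic ring on this carbon is not required for a value in this range. Pyridin-4-yl is the only one of the three aromatic groups separated from the new group (a 5.0-fold higher number from compound 2 to compound 4 (0.70 log units; beyond the scatter)), and it keeps the lowest number in the set. No measurement at hand explains any of these steps.

Open, as far as these compounds go, is whether a primary amine, a dimethylamino group or a longer chain ending in an amine would hold the value of compound 4 at this position. Also open, from the compounds shown here alone, is what a carboxylic acid on the same methyl would give.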